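This account rests on a few compounds, and the source may have more. Where it says the series, first, only, none or still open, it means among the compounds named here.

Compound 1 `O=C(Nc1ccc(Sc2nc3ccccc3s2)c(Cl)c1)c1ccccc1O` is the starting point of this comparison in an assay for inhibition of HSP60/HSP10 (Homo sapiens), with a stated time of 60 min; a higher number here means a weaker inhibitor, a lower number a stronger inhibitor. In this assay compound 1 gives only a limit, > 100000 nM, and not a number. Compound 2 `O=C(Nc1ccc(Sc2nc3ccccc3s2)cc1)c1ccccc1O` differs from compound 1 by hydrogen in place of chloro on an aromatic carbon. In this assay compound 2 also gives only a limit, > 100000 nM. Compound 3 `COc1c(Br)cc(Br)cc1C(=O)Nc1ccc(Sc2nc3ccccc3s2)cc1` likewise reaches only a limit in this assay, > 100000 nM. Among the measured compounds shown here, the single step between neighbours, a step that the two limits leave unreadable from compound 1 to compound 2, cannot be sized because both ends are limits. Where compound 1 stands is therefore known only as a limit, shared with the other two values: the limit of > 100000 nM in this assay, at which 3 of the 3 values shown sit.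

Compound 4 `O=C(Nc1ccc(Sc2nc3ccccc3s2)c(Cl)c1)c1cccc(Br)c1` has not been measured. Against compound 1 the change is 3-bromophenyl in place of 2-hydroxyphenyl on a carbonyl carbon. For the measured compounds named here, none of the measured steps touches this carbonyl carbon, and the one step that exists is unreadable, so no direction or size can be taken from the series; the only guidance is that every value in this assay so far is a limit.

For compound 4 in this assay the expectation is accordingly that the reading again sits at or near the limit, estimated at 150000 nM with a range from 30000 nM to 1000000 nM. The step this estimate implies is expected to be a step that the limit leaves unreadable from compound 1 to compound 4.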

Compound 4, half-maximal inhibitory concentration: > 100000 nM
Compound 4 was reported as a limit; the forecaster's own chance of this, stated with the estimate: 85%; the middle value is on the limit's open side.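

In this assay compound 4 gives > 100000 nM, which is a limit. Among the compounds shown here, compound 1 is also reported only as a limit, so no step from compound 1 to compound 4 can be read. The series stands at one limit: the limit of > 100000 nM in this assay, at which 4 of the 4 values shown sit. The compounds shown leave open whether 3-bromophenyl and 2-hydroxyphenyl on the carbonyl carbon differ at all, and what any compound's actual value is.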